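The source may hold more compounds than are shown below. What is called first, only, known or untested is meant among the compounds shown, and "the series" means these compounds.

Compound 1 `COc1ccc(-c2cc(/C=C/C(=O)c3ccc(N)cc3)[nH]n2)cc1` gives -82% in a functional assay on Malme-3M cells (Homo sapiens) for cytotoxicity, read by sulforhodamine B assay, with a stated time of 48 h, tested at 100 uM; on this read-out higher numbers stand for a weaker effect at the one concentration tested and lower numbers for a stronger effect.
Compound 2 `COc1cc(-c2cc(/C=C/C(=O)c3ccc(N)cc3)[nH]n2)cc(OC)c1OC` gives -76% in this assay.

On these two numbers compound 2 lies within the usual scatter of compound 1, so the two readings cannot be told apart. Compound 3 `COc1ccc(-c2cc(/C=C/C(=O)c3ccc(N)cc3)[nH]n2)cc1OC` differs from compound 2 in one place: hydrogen in place of methoxy on an aromatic carbon. Compound 1 and compound 2 already carry different numbers of methoxy groups and still agree in this assay. The step for compound 3 is expected to be none beyond the scatter, estimated as a number 2 percentage points lower from compound 2 to compound 3 (within the scatter). Compound 3 is expected to give about -78%, with a range from -95% to -60%.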

Compound 3, a percentage reported as activity, at one concentration (the size of the read-out at that concentration, not a potency): -75%
Beside the measured number, compound 3's estimate is 3 percentage points below it, and the stated range covers the measured number.
By their numbers in this assay, from the lowest: compounds 1, 2 and 3 (each within the scatter of the next).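

The earlier compounds shown here offered no single-place step, but compound 3 now provides two in this assay. Hydrogen in place of methoxy on an aromatic carbon gives a number 1 percentage points higher from compound 2 to compound 3 (within the scatter) and methoxy in place of hydrogen gives a number 7 percentage points higher from compound 1 to compound 3 (within the scatter), so either change leaves the reading within the scatter. No separate measurement bears on this result.

As far as these compounds go, whether an amine or a carboxylic acid on this carbon would shift the reading remains open. So does whether these compounds differ at lower concentrations.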